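The source may report more compounds than this note shows. Statements on the series, on what has been measured and on what is new or still open speak of the compounds shown alone.

Measured so far in an ADME assay on Vero cells (Chlorocebus sabaeus) for cytotoxicity, read by resazurin assay, with a stated time of 3 days; on this read-out higher numbers stand for weaker inhibition and lower numbers for stronger inhibition:

- compound 1, `CCCNC(=O)Nc1cc2nc(C3CCCCC3)[nH]c2cc1N(CC)CC`, gives a limit of the assay, > 100 ug/mL.
- compound 2, `CCN(CC)c1cc2[nH]c(C3CCCCC3)nc2cc1NC(=O)c1ccc(F)cc1F`, gives a limit of the assay, > 100 ug/mL.
- compound 3, `CCCCOC(=O)Nc1cc2nc(C3CCCCC3)[nH]c2cc1N(CC)CC`, gives a limit of the assay, > 100 ug/mL.

Compound 3 therefore stands where the other two stand: at the upper limit of this assay, with no number of its own to compare. The measured steps among these three are all unreadable for the same reason: a step that the two limits leave unreadable from compound 1 to compound 2, a step that the two limits leave unreadable from compound 1 to compound 3 and a step that the two limits leave unreadable from compound 2 to compound 3. The shared picture is given by the limit of > 100 ug/mL in this assay, at which 3 of the 3 values shown sit.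

The step to compound 4, `CCN(CC)c1cc2[nH]c(C3CCCCC3)nc2cc1NC(=O)c1ccc(F)cc1`, is 4-fluorophenyl in place of butoxy on a carbonyl carbon. Going by the values given here, no measured step bears on this change in a readable way; the step from compound 2 to compound 3 touches the same carbonyl carbon but sits between two limits. Compound 2, which already carries a fluorinated phenyl ring on that carbonyl, gave a limit. On that basis the expected step that the limit leaves unreadable from compound 3 to compound 4 is none beyond the scatter, and compound 4 is estimated at 150 ug/mL, most likely again reported only as a limit, with a range of 60 ug/mL to 400 ug/mL.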

Compound 4, half-maximal inhibitory concentration: > 100 ug/mL
Compound 4 gave a limit, no number (the forecaster's own chance of this, stated with the estimate: 85%); the middle value is on the limit's open side.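

No new step can be read in this assay among compound 1, compound 2, compound 3 and compound 4, since all four share one limit: the limit of > 100 ug/mL in this assay, at which 4 of the 4 values shown sit. The compounds shown leave open whether any change on the carbonyl carbon shifts this read-out, as none has a number of its own.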